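A few compounds are considered here, and "the series" means these few. Any claim that something is new, unique, unknown or untested is made for them only; others in the source may bear on it.

Compound 1 `O=C(N/N=C/c1ccc(-c2ccc(F)cc2F)o1)c1ccccc1O` stands highest of the three numbers in a functional assay on Bel-7402 cells (Homo sapiens) for inhibition, read by sulforhodamine B assay, with a stated time of 48 h, tested at 10 uM (a higher number here means more inhibition of growth at the concentration tested, a lower number less inhibition of growth), where compound 1 gives 63.4%. Compound 2 `O=C(N/N=C/c1ccc(-c2ccccc2F)o1)c1ccc(Cl)cc1` gives 2.96% and compound 3 `COc1ccccc1C(=O)N/N=C/c1ccc(-c2ccc(F)cc2F)o1` gives 1.69%; both fall far below compound 1, beyond the scatter. Within the data shown here, the only single-place step measured runs a number 61.7 percentage points lower from compound 1 to compound 3 (beyond the scatter), a methyl in place of hydrogen on an oxygen on an aromatic ring. Compound 2 differs from compound 1 in two places at once, so only its two values can be set side by side.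

Compound 4 `O=C(N/N=C/c1ccc(-c2ccc(F)cc2)o1)c1ccccc1O` differs from compound 1 by hydrogen in place of fluoro on an aromatic carbon: fluoro leaves and hydrogen enters on an aromatic carbon of a six-membered aromatic ring of carbon only, ortho to a large group and meta to a fluoro group, so the 2,4-difluorophenyl becomes 4-fluorophenyl. Among the measured compounds shown here, no measured step touches this ring alone; the one known step concerns the oxygen on the other ring and does not bear on it. The expectation therefore rests on compound 1 alone, and the step of a number 18.4 percentage points lower from compound 1 to compound 4 (beyond the scatter) is estimated with a wide range. Compound 4 is expected to give 45%, between 10% and 70%.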

Compound 4, percent growth inhibition at one concentration: 81.6%
Compound 4: the middle estimate sits 36.6 percentage points below what was measured, and the stated range ends below it.
By their numbers in this assay, from the lowest: compounds 3 and 2 (each within the scatter of the next); then compound 1; then compound 4.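

Hydrogen in place of fluoro on this aromatic carbon, ortho to a large group and meta to a fluoro group, gives a number 18.2 percentage points higher from compound 1 to compound 4 (beyond the scatter) in this assay, so the 2,4-difluorophenyl is not needed here and the 4-fluorophenyl does better. Among these compounds, this is the first measured step on this ring, and it runs upward, whereas the step on the oxygen of the other ring, a number 61.7 percentage points lower from compound 1 to compound 3 (beyond the scatter), runs downward. Nothing at hand accounts for the rise.

Still open, as far as these compounds go, is whether another group on this aromatic carbon, such as chloro, methyl or an amine, would hold the higher number. Also open, from the compounds shown here alone, is whether the gain persists when the oxygen of the other ring carries a methyl, as in compound 3.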